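The source may report more compounds than this note shows. Statements on the series, on what has been measured and on what is new or still open speak of the compounds shown alone.

Within the data shown here, compound 2 `Cn1c(=O)c(C(=O)Nc2ccccc2N)c(O)c2ccccc21` stands at the top of the two numbers measured so far in a functional assay, with a stated time of 60 min, tested at 0.5 mM; on this read-out higher numbers stand for a stronger effect at the one concentration tested and lower numbers for a weaker effect: in this assay compound 2 gives 41.4%, whereas compound 1 `Cn1c(=O)c(C(=O)NCCCCCCN)c(O)c2ccccc21` gives 21.9%. Among the measured compounds shown here, the single measured step, a number 19.5 percentage points higher from compound 1 to compound 2 (beyond the scatter), arises from 2-aminophenyl in place of 6-aminohexyl on an amide-type nitrogen. Compound 3 `Cn1c(=O)c(C(=O)Nc2ccc(N)cc2)c(O)c2ccccc21` has not yet been tested in this assay. It differs from compound 2 in one place: 4-aminophenyl in place of 2-aminophenyl on an amide-type nitrogen. For the measured compounds named here, no measured step concerns such a change: the one step on record, a number 19.5 percentage points higher from compound 1 to compound 2 (beyond the scatter), exchanges a chain for an aryl group and has a different character, and nothing shows how the two aminophenyl groups compare with each other in this assay. The expectation for compound 3 therefore rests on compound 2 alone, and it is estimated that compound 3 will show no step beyond the scatter, a number 1.4 percentage points lower from compound 2 to compound 3 (within the scatter). Compound 3 is accordingly expected to give about 40% in this assay, within a wide range of 20% to 60%.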

Compound 3, a percentage reported as activity, at one concentration (the size of the read-out at that concentration, not a potency): 83.7%
Beside the measured number, compound 3's estimate is 43.7 percentage points below it; measured number above the stated range.
By their numbers in this assay, from the lowest: compound 1; then compound 2; then compound 3.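

In this assay, 4-aminophenyl and 2-aminophenyl on the amide-type nitrogen have the same atoms and the same counted features and differ only in how those atoms are joined, yet this change alone gives a number 42.3 percentage points higher from compound 2 to compound 3 (beyond the scatter) on the shared core, so the read-out at this position depends on the arrangement within the aminophenyl group and not merely on the presence of an aryl amine. The earlier step from the 6-aminohexyl chain to an aryl group therefore gave only a partial picture, since 4-aminophenyl in place of 6-aminohexyl gives a number 61.8 percentage points higher from compound 1 to compound 3 (beyond the scatter) and puts compound 3 highest of the three, with its steps to both others beyond the scatter. Nothing available explains why the two aminophenyl groups part so widely.

The compounds shown leave open where 3-aminophenyl would fall on this read-out, and whether the amine itself matters, which a plain phenyl or a 4-hydroxyphenyl group on the same nitrogen would address. On these data alone, all of these numbers also describe the effect at a single concentration, so whether the effect of the compounds would be stronger or weaker at any other concentration remains open.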